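A few compounds are considered here, and "the series" means these few. Any claim that something is new, unique, unknown or untested is made for them only; others in the source may bear on it.

Measured compounds:
compound 1, `O=C(Nc1cccc(F)c1)C(Cl)Cl`: "not determined" (no result reported)
compound 2, `O=C(Nc1cccc(OC(F)(F)F)c1)C(Cl)Cl`: 15100 nM

Two compounds share the dichloroacetamide core, and only one of them carries a number. In a functional assay on A549 cells (Homo sapiens) for antiproliferative activity, read by MTT assay, with a stated time of 72 h (on this read-out higher numbers stand for weaker inhibition and lower numbers for stronger inhibition), compound 2 gives 15100 nM; for compound 1 the entry in this assay reads "not determined" (no result reported), so compound 2 stands alone on the figures shown and no comparison between measured compounds can be drawn.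

Compound 3 `O=C(Nc1cccc(SC(F)(F)F)c1)C(Cl)Cl` has not yet been measured in this assay. It differs from compound 2 by (trifluoromethyl)sulfanyl in place of trifluoromethoxy on an aromatic carbon. Among the compounds with values here, no step between measured compounds is available to guide this change, so the expectation rests on compound 2 alone. The step from compound 2 to compound 3 is expected to fall within the scatter, a 1.3-fold lower number from compound 2 to compound 3 (0.10 log units; within the scatter), with no clear direction. Compound 3 is therefore estimated at 12000 nM, within a range from 5000 nM to 30000 nM in this assay.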

Compound 3, half-maximal inhibitory concentration: 14100 nM
The estimate for compound 3 lay 1.2-fold (0.07 log units) below the measured number; the range from low to high includes it.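

In this assay the series now has its first step between measured compounds, and a 1.1-fold lower number from compound 2 to compound 3 (0.03 log units; within the scatter) for the exchange of trifluoromethoxy for (trifluoromethyl)sulfanyl on an aromatic carbon. At this position, meta to a group of 6 heavy atoms, the two groups therefore cannot be told apart on this read-out, although the earlier figures, with one number only, could not address this. Nothing measured alongside these compounds speaks to what lies behind this agreement.

Compound 1 has no number, so its fluoro group cannot be compared with either of the other two groups. Also open, from the compounds shown here alone, is whether a group of another kind on this aromatic carbon, such as an amine or a carboxylic acid, would give a step beyond the scatter.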